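A few compounds are considered here, and "the series" means these few. Any claim that something is new, unique, unknown or untested is made for them only; others in the source may bear on it.

Working notes on the nitrogen substituent of the shared core.

Compound 1 `O=C1NC(=O)C(c2ccccc2)CC1c1ccccc1` carries hydrogen on the ring nitrogen, and in a functional assay on the whole organism (strain Swiss albino) for inhibition, with Mus musculus as the target, in the maximal electroshock model, with a stated time of 2 h, at a dose of 25 mg/kg by the intraperitoneal route (on this read-out lower numbers stand for less inhibition and higher numbers for more inhibition at the one dose given (going by the name of the read-out)), compound 1 gives 70.2%. Compound 2 `CN1C(=O)C(c2ccccc2)CC(c2ccccc2)C1=O` carries methyl there, and in this assay compound 2 gives 69.1%. Compound 3 `O=C1C(c2ccccc2)CC(c2ccccc2)C(=O)N1Cc1ccccc1` carries benzyl, and in this assay compound 3 gives 64.5%. Compound 3 sits at the lower end of the three numbers, but the gap to each of the other two is within the scatter: a number 5.7 percentage points lower from compound 1 to compound 3 (within the scatter), a number 4.6 percentage points lower from compound 2 to compound 3 (within the scatter), and likewise a number 1.1 percentage points lower from compound 1 to compound 2 (within the scatter). Every change made at the ring nitrogen so far has therefore left the read-out essentially where it was.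

Compound 4 `Cc1ccccc1N1C(=O)C(c2ccccc2)CC(c2ccccc2)C1=O` differs from compound 3 by 2-methylphenyl in place of benzyl on an amide-type nitrogen in a ring. All three measured steps bear on this change, since each also alters only the group on the ring nitrogen, and each was within the scatter. No step beyond the scatter is therefore expected, and the expected step is a number 1.5 percentage points lower from compound 3 to compound 4 (within the scatter). For compound 4 in this assay the estimate is 63%, with a range from 48% to 78%.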

Compound 4, a percentage reported as inhibition, in the whole organism at one dose (the size of the read-out at that dose, not a potency): 66.1%
The estimate for compound 4 lay 3.1 percentage points below the measured number; the range from low to high includes it.
By their numbers in this assay, from the lowest: compounds 3, 4, 2 and 1 (each within the scatter of the next).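

Benzyl and 2-methylphenyl have the same atoms, joined differently, and in this assay exchanging one for the other on the amide-type nitrogen gives a number 1.6 percentage points higher from compound 3 to compound 4 (within the scatter). The same group set against the smaller substituents gives a number 3 percentage points lower from compound 2 to compound 4 (within the scatter) and a number 4.1 percentage points lower from compound 1 to compound 4 (within the scatter), so the read-out at this position stays level across hydrogen, methyl, benzyl and now 2-methylphenyl. No accompanying measurement bears on this result.

The compounds shown carry only hydrogen or hydrocarbon groups on the ring nitrogen, so it remains open whether a longer chain ending in an amine or a carboxylic acid would also leave the read-out level. Because all four numbers come from one dose, they also leave open whether potency differs across the series.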